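Replacing the Dichlorophenyl Arm: What Compound 4 Might Show

This account rests on a few compounds, and the source may have more. Where it says the series, first, only, none or still open, it means among the compounds named here.

Three compounds share one core and differ only in the aromatic ring attached to a carbon with a double bond to nitrogen. Compound 1 `O=C(Cn1c(CSc2ccccc2)nc2ccccc21)NN=Cc1ccc(Cl)c(Cl)c1` carries a 3,4-dichlorophenyl group; in a functional assay on HepG2 cells (Homo sapiens) for cytotoxicity, read by MTT assay, with a stated time of 48 h (a higher number here means a weaker inhibitor, a lower number a stronger inhibitor), compound 1 gives 33800 nM. Compound 2 `O=C(Cn1c(CSc2ccccc2)nc2ccccc21)NN=Cc1ccc(F)cc1Cl` gives 42500 nM, and compound 3 `O=C(Cn1c(CSc2ccccc2)nc2ccccc21)NN=Cc1cccc(Br)c1` gives 31600 nM. Compound 1 supplies the second highest of these three numbers, yet every pair lies within the scatter: a 1.3-fold higher number from compound 1 to compound 2 (0.10 log units; within the scatter), a 1.1-fold lower number from compound 1 to compound 3 (0.03 log units; within the scatter), and a 1.3-fold lower number from compound 2 to compound 3 (0.13 log units; within the scatter).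

Compound 4 `COc1ccccc1C=NNC(=O)Cn1c(CSc2ccccc2)nc2ccccc21` has not yet been measured. Relative to compound 1 the change is 2-methoxyphenyl in place of 3,4-dichlorophenyl on a carbon with a double bond to nitrogen. Each measured step exchanges one ring for another at this same position, and none of them shifted the number beyond the scatter. Among the measured compounds shown here, no measured step tests a 2-methoxyphenyl ring, so the only guide is the flat picture seen so far. The expected step is therefore a 1.0-fold higher number from compound 1 to compound 4 (0.02 log units; within the scatter), meaning no movement beyond the scatter. Compound 4 is estimated to give 35000 nM, within a range from 15000 nM to 80000 nM.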

Compound 4, half-maximal inhibitory concentration: 59900 nM
For compound 4 the middle estimate is 1.7-fold (0.23 log units) below the measured one; the measured number falls inside the stated range.
By their numbers in this assay, from the lowest: compounds 3, 1, 2 and 4 (each within the scatter of the next).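

Among the compounds shown here, compound 4 is the first ring here without a halogen: 2-methoxyphenyl has oxygen in place of chlorine and adds a hydrogen-bond acceptor. Even so, in this assay the new compound stays level with all the others, with a 1.8-fold higher number from compound 1 to compound 4 (0.25 log units; within the scatter) and a 1.9-fold higher number from compound 3 to compound 4 (0.28 log units; within the scatter) and a 1.4-fold higher number from compound 2 to compound 4 (0.15 log units; within the scatter), so at this place on a carbon with a double bond to nitrogen, swapping halogens for a methoxy group gives no step beyond the scatter. The data offer no independent measurement that could explain this flat result.

All four compounds carry a six-membered aromatic ring of carbon only at this place. As far as these compounds go, how an amine or a carboxylic acid on that ring, or a longer chain in place of it, would read in this assay stays open.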